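Anilinoquinazoline thioethers against a breast cancer line

The compounds below may be only part of what the source reports. "The series", "measured", "known", "first", "only" and "open" are said of these compounds alone.

Measured so far:
- compound 1 `COc1ccccc1Nc1nc(SCc2ccc(C(F)(F)F)cc2)nc2ccccc12`: > 50000 nM
- compound 2 `Cc1ccc(Nc2nc(SCc3ccc(C(F)(F)F)cc3)nc3ccccc23)cc1`: > 50000 nM

In a functional assay on MDA-MB-231 cells (Homo sapiens) for cytotoxicity, read by MTT assay, with a stated time of 72 h (on this read-out lower numbers stand for stronger inhibition and higher numbers for weaker inhibition), compound 2 gives > 50000 nM, which is a limit of the assay and not a number. Compound 1 likewise reaches only > 50000 nM, again a limit. The step that the two limits leave unreadable from compound 1 to compound 2 therefore cannot be read. (the limit of > 50000 nM in this assay, at which 2 of the 2 values shown sit).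

Compound 3 `COc1cc(Nc2nc(SCc3ccc(C(F)(F)F)cc3)nc3ccccc23)cc(OC)c1` differs from compound 2 by 3,5-dimethoxyphenyl in place of 4-methylphenyl on a nitrogen on an aromatic ring. Among the measured compounds shown here, no measured step bears on this change, and both neighbours sit at the limit. Compound 3 is expected to show a step that the limit leaves unreadable from compound 2 to compound 3, with no reading beyond the limit likely. Compound 3 is estimated at 60000 nM, between 15000 nM and 250000 nM.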

Compound 3, half-maximal inhibitory concentration: 16100 nM
Compound 3: the middle estimate sits 3.7-fold (0.57 log units) above what was measured; the measured number falls inside the stated range.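

In this assay, among the compounds shown here, compound 3 gives 16100 nM as the only reading that is a number. With 3,5-dimethoxyphenyl on the nitrogen, the read-out shows an at least 3.1-fold lower number from compound 2 to compound 3 (0.49 log units; beyond the scatter) and an at least 3.1-fold lower number from compound 1 to compound 3 (0.49 log units; beyond the scatter) as well, so the group at this position can move the read-out, which the two earlier compounds could not show. Both steps give only a minimum size: the limit of > 50000 nM in this assay, at which 2 of the 3 values shown sit.

Still open, on these data alone, is whether the shift needs both methoxy groups of 3,5-dimethoxyphenyl. Also open, as far as these compounds go, is how a carboxylic acid or a morpholine on this aromatic ring would read.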